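The source may report more compounds than this note shows. Statements on the series, on what has been measured and on what is new or still open speak of the compounds shown alone.

In a functional assay on HepG2 cells (Homo sapiens) for antiproliferative activity, read by MTT assay, with a stated time of 48 h (on this read-out lower numbers stand for stronger inhibition and higher numbers for weaker inhibition), compound 1 `Fc1ccccc1N1CCN(Cn2nc(-c3ccc4c(c3)OCCO4)oc2=S)CC1` gives > 50000 nM, which is a limit of the assay. Compound 2 `S=c1oc(-c2ccc3c(c2)OCCO3)nn1CN1CCN(c2cccc(Cl)c2Cl)CC1` gives > 50000 nM, also a limit. Among the measured compounds shown here, compound 3 `COc1ccccc1N1CCN(Cn2nc(-c3ccc4c(c3)OCCO4)oc2=S)CC1` gives 15500 nM, the only actual number so far. Compound 4 `COc1ccc(N2CCN(Cn3nc(-c4ccc5c(c4)OCCO5)oc3=S)CC2)cc1` is the next structure, with this change: 4-methoxyphenyl in place of 2-methoxyphenyl on an amine nitrogen in a ring. For the measured compounds named here, two measured steps bear on it: an at least 3.2-fold lower number from compound 1 to compound 3 (0.50 log units; beyond the scatter) and an at least 3.2-fold lower number from compound 2 to compound 3 (0.50 log units; beyond the scatter). From the compounds shown here alone, both start from a limit, so their full size stays open, and neither tests where the methoxy group sits. No step beyond the scatter is therefore expected, and the estimated step is a 1.3-fold higher number from compound 3 to compound 4 (0.11 log units; within the scatter). The expected value for compound 4 is 20000 nM, with an estimated range of 6000 nM to 50000 nM.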

Compound 4, half-maximal inhibitory concentration: > 50000 nM
Compound 4 ended at the assay's limit; the forecaster's own chance of this, stated with the estimate: 25%; middle value at least 2.5-fold (0.39 log units) from the limit.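

In this assay, among the compounds shown here, the place of the methoxy group on the phenyl ring counts, with an at least 3.2-fold higher number from compound 3 to compound 4 (0.50 log units; beyond the scatter) as the first step that tests it; its full size stays open, as compound 4 sits at a limit of the assay. Among the compounds shown, only the 2-methoxyphenyl group gives a number rather than a limit. The steps from compound 1 and compound 2 to compound 4 cannot be read: the limit of > 50000 nM in this assay, at which 3 of the 4 values shown sit.

Open, from the compounds shown here alone, is whether a 2-ethoxyphenyl or 2-hydroxyphenyl group keeps a measurable number. Also open, going by these compounds, is how far any group can lower the number of compound 3.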